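A few compounds are considered here, and "the series" means these few. Any claim that something is new, unique, unknown or untested is made for them only; others in the source may bear on it.

Compound 2 is `CN1CCC(C(=O)N2Cc3c(NC(=O)C4CCC4)n[nH]c3C2(C)C)CC1`. In a physicochemical assay for solubility, at pH 7 (a lower number here means a less soluble compound, a higher number a more soluble compound), compound 2 gives > 225000 nM, and this is a limit of the assay rather than a number. Two closely related compounds share the same core. Compound 1 is `CC(C)(C)C(=O)N1Cc2c(NC(=O)C3CCNCC3)n[nH]c2C1(C)C`, and in this assay compound 1 gives > 225000 nM, again a limit. Compound 3 is `CN(C)CC(=O)Nc1n[nH]c2c1CN(C(=O)C(C)(C)C)C2(C)C`, and in this assay compound 3 gives > 225000 nM, also a limit. Going by the values given here, the one change that can be paired, a step that the two limits leave unreadable from compound 1 to compound 3, cannot be sized because both ends sit at the limit of > 225000 nM in this assay, at which 3 of the 3 values shown sit. So all three compounds stand at the same edge of what this measurement can report, and none of them is distinguishable from another on these numbers.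

Compound 4 is `CN1CCC(C(=O)N2Cc3c(NC(=O)c4cccc(F)c4)n[nH]c3C2(C)C)CC1`. Compared with compound 2, the change is 3-fluorophenyl in place of cyclobutyl on a carbonyl carbon. Among the compounds with values here, no measured step involves this kind of change, and the only recorded step gives no readable size, so there is nothing to project from. The expectation is therefore that the step of an at least 1.5-fold lower number from compound 2 to compound 4 (0.17 log units; that floor lies within the scatter) will be modest, with compound 4 staying near the limit but with a fair chance of a readable value somewhat below it. For compound 4 the estimate in this assay is 150000 nM, within a range from 30000 nM to 225000 nM.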

Compound 4, solubility: > 225000 nM
Compound 4: no number, only a limit (the forecaster's own chance of this, stated with the estimate: 40%); at least 1.5-fold (0.17 log units) between middle value and limit.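

Going by these compounds alone, compound 2 and compound 4 both stand at a limit of this assay rather than at a number, so putting 3-fluorophenyl in place of cyclobutyl gives no step of readable size. What the compounds shown leave open is whether any of these changes alters the read-out of this assay, since all of them share one edge: the limit of > 225000 nM in this assay, at which 4 of the 4 values shown sit.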